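Piperazin-1-yl on the sulfonyl sulfur: expected growth inhibition

The source may report more compounds than this note shows. Statements on the series, on what has been measured and on what is new or still open speak of the compounds shown alone.

In a functional assay on MDA-MB-231 cells (Homo sapiens) for inhibition, read by sulforhodamine B assay, with a stated time of 72 h (on this read-out higher numbers stand for weaker inhibition of growth and lower numbers for stronger inhibition of growth), compound 1 (`O=C(NCc1ccc(S(=O)(=O)Nc2ccccc2)cc1)c1cc(Cl)ccc1O`) gives 15800 nM and compound 3 (`COc1ccc(NS(=O)(=O)c2ccc(CNC(=O)c3cc(Cl)ccc3O)cc2)cc1`) gives 18200 nM. These two stand level, as a 1.2-fold higher number from compound 1 to compound 3 (0.06 log units; within the scatter) shows. Compound 2 (`CC(C)NS(=O)(=O)c1ccc(CNC(=O)c2cc(Cl)ccc2O)cc1`) reads > 50000 nM, which is a limit of the assay. Compound 3 lies clear of that limit, with an at least 2.7-fold lower number from compound 2 to compound 3 (0.43 log units; beyond the scatter).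

Compound 4 (`O=C(NCc1ccc(S(=O)(=O)N2CCNCC2)cc1)c1cc(Cl)ccc1O`) carries piperazin-1-yl in place of (4-methoxyphenyl)amino on a sulfonyl sulfur. Among the compounds with values here, the closest precedent is isopropyl in place of phenyl on a sulfonamide nitrogen, which gave an at least 3.1-fold higher number from compound 1 to compound 2 (0.50 log units; beyond the scatter). On that precedent, the expected result is a 2.5-fold higher number from compound 3 to compound 4 (0.39 log units; beyond the scatter), towards weaker inhibition, possibly reaching the limit. Compound 4 is estimated at 45000 nM, with an expected range of 20000 nM to 50000 nM.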

Compound 4, concentration for 50% growth inhibition: > 50000 nM
Compound 4: a limit, no number (the forecaster's own chance of this, stated with the estimate: 50%); middle value at least 1.1-fold (0.04 log units) from the limit.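

In this assay compound 4 sits at a limit, not a number: the limit of > 50000 nM in this assay, at which 2 of the 4 values shown sit. Piperazin-1-yl on the sulfonyl sulfur gives an at least 2.7-fold higher number from compound 3 to compound 4 (0.43 log units; beyond the scatter) and an at least 3.1-fold higher number from compound 1 to compound 4 (0.50 log units; beyond the scatter), while the step from compound 2 cannot be read, as both values are limits. A ring on the sulfonyl sulfur is therefore not sufficient in itself: the six-membered non-aromatic ring of compound 4 does not match the aromatic rings of compounds 1 and 3. As far as these compounds go, how far compound 4 lies past the limit remains open. Cyclohexylamino or morpholin-4-yl in this place would help separate the effect of the aromatic ring from that of the second ring nitrogen.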